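A Methyl on the Ring Nitrogen of Compound 2

The compounds below may be only part of what the source reports. "The series", "measured", "known", "first", "only" and "open" are said of these compounds alone.

Compound 1 `Fc1cccc(F)c1C#Cc1ccc2[nH]ncc2c1` and compound 2 `Fc1cccc(F)c1C#Cc1ccc2cn[nH]c2c1` are built from the same atoms joined differently; the difference between the two cores is not broken down here. In a functional assay on LS174T cells (Homo sapiens) for inhibition, with a stated time of 4 days, tested at 10 uM (a higher number here means a stronger effect of the compound at the concentration tested, a lower number a weaker effect), compound 1 gives 82.9%, and in the same assay compound 2 gives 97%. Compound 3 `Cn1ncc2cc(C#Cc3c(F)cccc3F)ccc21` differs from compound 1 by methyl in place of hydrogen on an aromatic nitrogen. In this assay compound 3 gives 94.6%, which means a number 11.7 percentage points higher from compound 1 to compound 3 (beyond the scatter); compound 3 and compound 2 lie within the scatter of each other.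

Compound 4 `Cn1ncc2ccc(C#Cc3c(F)cccc3F)cc21` has not been measured. It differs from compound 2 by methyl in place of hydrogen on an aromatic nitrogen, the same change that separates compound 1 from compound 3. For compound 4 the expected step in this assay is a number 1 percentage points lower from compound 2 to compound 4 (within the scatter), smaller than the measured one, because compound 2 already gives 97% and a read-out expressed as inhibition has little room left above it. Compound 4 is therefore estimated at 96%, most likely between 88% and 100%.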

Compound 4, a percentage reported as inhibition, at one concentration (the size of the read-out at that concentration, not a potency): 98.1%
The estimate for compound 4 lay 2.1 percentage points below the measured number; the range from low to high includes it.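

In this assay methyl in place of hydrogen on the aromatic nitrogen gives a number 1.1 percentage points higher from compound 2 to compound 4 (within the scatter), so on this core the change makes no difference that can be read. Set beside the same change on the core of compound 1, the two steps cannot be told apart: the same change on two cores in this assay, a number 11.7 percentage points higher (beyond the scatter) from compound 1 to compound 3 and a number 1.1 percentage points higher (within the scatter) from compound 2 to compound 4, 10.6 percentage points apart, within the scatter of two such steps. This shows that compound 3 and compound 4 both keep a high read-out at the one concentration tested, but it does not show that the change has one size on both cores, and a percentage at a single concentration gives no potency.

The compounds shown leave open what a longer chain such as ethyl, or a chain ending in an amine, would do on the same aromatic nitrogen in this assay. They also leave open whether compound 2 and compound 4 would still stand together at lower concentrations, where the read-out would have room to separate them.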